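A second chloro on compound 3

This account rests on a few compounds, and the source may have more. Where it says the series, first, only, none or still open, it means among the compounds named here.

Measured in a functional assay on HL-60 cells (Homo sapiens) for cytotoxicity, read by WST assay, with a stated time of 48 h; on this read-out higher numbers stand for an effect only at larger amounts of compound and lower numbers for an effect already at smaller amounts:
- compound 1 `O=C1OC[C@H](Cc2ccccc2)[C@H]1Cc1cccc(Cl)c1`: 36000 nM
- compound 2 `O=C1OC[C@H](Cc2ccccc2)[C@H]1Cc1ccc(OC(F)(F)F)cc1`: 27000 nM
- compound 3 `O=C1OC[C@H](Cc2ccccc2)[C@H]1Cc1ccc(Cl)cc1`: 36000 nM

Compound 3 stands level with compound 1 and within the scatter of compound 2. Compound 4 `O=C1OC[C@H](Cc2ccccc2)[C@H]1Cc1ccc(Cl)c(Cl)c1` differs from it by one change: chloro in place of hydrogen on an aromatic carbon, ortho to a chloro group. It thus carries the chloro groups of compound 1 and compound 3 together. Going by the values given here, two measured steps bear on this: no change at the digits printed from compound 1 to compound 3 (within the scatter), and a 1.3-fold higher number from compound 2 to compound 3 (0.12 log units; within the scatter). Neither puts a group in place of hydrogen, so the evidence is indirect. No shift beyond the scatter is expected in this assay. The expected step is a 1.2-fold lower number from compound 3 to compound 4 (0.08 log units; within the scatter). For compound 4 the estimated value is 30000 nM, with an expected range of 15000 nM to 55000 nM.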

Compound 4, half-maximal effective concentration: 19000 nM
Beside the measured number, compound 4's estimate is 1.6-fold (0.20 log units) above it, within the range that was stated.
By their numbers in this assay, from the lowest: compounds 4, 2, 1 and 3 (each within the scatter of the next).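

In this assay, a second chloro on the aromatic ring gives a 1.9-fold lower number from compound 3 to compound 4 (0.28 log units; within the scatter), and a 1.9-fold lower number from compound 1 to compound 4 (0.28 log units; within the scatter). Unlike the earlier steps, which moved or exchanged a group, these two put a group in place of hydrogen, here ortho to a chloro group, and both stay within the usual scatter. Nothing measured here offers an explanation for this result. Going by these compounds, it remains open whether an amine or a carboxylic acid at this position would likewise stay within the scatter, and whether the same holds for a methoxy group.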